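Removing the methoxy group from the anilino ring of compound 1

The compounds below may be only part of what the source reports. "The series", "measured", "known", "first", "only" and "open" are said of these compounds alone.

Measured compounds:
- Compound 1, `COc1ccc(Nc2cc(-c3ccccc3)oc(=O)c2)cc1`: 0.16 uM
- Compound 2, `COc1ccc(Nc2cc(C3CCCC3)oc(=O)c2)cc1`: 8.38 uM
- Compound 3, `COc1ccc(Nc2cc(/C=C/c3ccccc3)oc(=O)c2)cc1`: 0.15 uM

In a functional assay on KB cells (Homo sapiens) for cytotoxicity, read by MTT assay, with a stated time of 72 h (on this read-out lower numbers stand for an effect already at smaller amounts and higher numbers for an effect only at larger amounts of compound), compound 1 gives 0.16 uM, the second highest of the three numbers. Its nearest neighbour is compound 3, and the step of a 1.1-fold lower number from compound 1 to compound 3 (0.03 log units; within the scatter) lies within the scatter. Within the data shown here, the step of a 52-fold higher number from compound 1 to compound 2 (1.72 log units; beyond the scatter) is the one large change seen so far, and the step of a 56-fold lower number from compound 2 to compound 3 (1.75 log units; beyond the scatter) mirrors it.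

Compound 4, `O=c1cc(Nc2ccccc2)cc(-c2ccccc2)o1`, is not yet measured. It differs from compound 1 by one change, (hydrogen in place of methoxy on an aromatic carbon). Among the measured compounds shown here, every measured step alters the group on the other aromatic carbon of the shared core, while the methoxy group is kept in all three measured compounds, so no measured step bears directly on this change. The two measured steps that keep an aromatic group in place stay within the scatter, whereas the change to cyclopentyl is large. With nothing to anchor the change at the methoxy position, a small rise in this assay, close to or a little beyond the scatter, is expected for compound 4, namely a 2.2-fold higher number from compound 1 to compound 4 (0.34 log units; beyond the scatter). The estimate for compound 4 is 0.35 uM, with a range from 0.08 uM to 1.5 uM.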

Compound 4, concentration for half-maximal effect: 0.13 uM
Beside the measured number, compound 4's estimate is 2.7-fold (0.43 log units) above it; measured number inside the range.
By their numbers in this assay, from the lowest: compounds 4, 3 and 1 (each within the scatter of the next); then compound 2.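

In this assay, among these compounds, the new compound gives the first direct reading at this position: hydrogen in place of methoxy, para to a large group, gives a 1.2-fold lower number from compound 1 to compound 4 (0.09 log units; within the scatter) and so leaves the number within the scatter. With phenyl on the other aromatic carbon of the shared core, the methoxy group can therefore go without a measurable change, whereas the change at that other carbon gives a 52-fold higher number from compound 1 to compound 2 (1.72 log units; beyond the scatter) and is large. Nothing in the data explains why this step is so small.

The compounds shown leave open whether an amine, a carboxylic acid or a longer chain on this carbon would also leave the number within the scatter. They also leave open whether hydrogen in place of methoxy would read the same with cyclopentyl or 2-phenylethenyl on the other aromatic carbon.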